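The compounds below may be only part of what the source reports. "The series", "measured", "known", "first", "only" and "open" are said of these compounds alone.

In an ADME assay on L6 cells (Rattus norvegicus) for cytotoxicity (on this read-out higher numbers stand for weaker inhibition and lower numbers for stronger inhibition), compound 1 `CN1CCN(CCCN2CCC3(N(C)C)CC(c4ccccc4)C2C(c2ccccc2)C3)CC1` gives 54500 nM, and compound 2 `CN1CCN(CCCN2CCC3(N4CCN(C)CC4)CC(c4ccccc4)C2C(c2ccccc2)C3)CC1` gives 47800 nM. Within the data shown here, the only measured step, a 1.1-fold lower number from compound 1 to compound 2 (0.06 log units; within the scatter), is within the scatter, so compound 2 stands with the lower of the two numbers but is not separated from compound 1. Compound 3 `CN1CCN(CCCN2CCC3(N4CCCCC4)CC(c4ccccc4)C2C(c2ccccc2)C3)CC1` differs from compound 2 by piperidin-1-yl in place of 4-methylpiperazin-1-yl on a saturated ring carbon, a change at the same saturated ring carbon that the step from compound 1 to compound 2 touched. Since that step was within the scatter, no step beyond the scatter is expected in this assay for compound 3, which is estimated at 50000 nM (range 25000 nM to 100000 nM), an expected step of a 1.0-fold higher number from compound 2 to compound 3 (0.02 log units; within the scatter).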

Compound 3, half-maximal inhibitory concentration: 62500 nM
Compound 3: the middle estimate sits 1.3-fold (0.10 log units) below what was measured; the measured number falls inside the stated range.
By their numbers in this assay, from the lowest: compounds 2, 1 and 3 (each within the scatter of the next).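

In this assay, piperidin-1-yl, with one hetero atom in its ring where 4-methylpiperazin-1-yl has two, gives a 1.3-fold higher number from compound 2 to compound 3 (0.12 log units; within the scatter), and in place of dimethylamino it gives a 1.1-fold higher number from compound 1 to compound 3 (0.06 log units; within the scatter). The three amino groups on this saturated ring carbon, now including a ring with a single hetero atom, are therefore not separated in this assay. No supporting evidence bears on this result.

The compounds shown leave open whether a carboxylic acid or a primary amine on this carbon would give a step beyond the scatter. They also leave open what a fluorine on the phenyl groups would do.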